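Amide to Urea: What Compound 4 Should Show

This account rests on a few compounds, and the source may have more. Where it says the series, first, only, none or still open, it means among the compounds named here.

Three compounds have been measured in a functional assay on CCRF-CEM cells (Homo sapiens) for inhibition, read by sulforhodamine B assay, with a stated time of 48 h; on this read-out lower numbers stand for stronger inhibition of growth and higher numbers for weaker inhibition of growth:
Compound 1, `COc1cc(-c2nn(-c3cccc(NC(=O)c4cccc(C(F)(F)F)c4)c3)cc2-c2ccncc2)ccc1Cl`, gives 1450 nM.
Compound 2, `COc1cc(-c2nn(-c3cccc(NC(=O)Nc4cccc(C(F)(F)F)c4)c3)cc2-c2ccncc2)ccc1Cl`, gives 945 nM.
Compound 3, `COc1cc(-c2nn(-c3cccc(NC(=O)c4ccc(Cl)c(C(F)(F)F)c4)c3)cc2-c2ccncc2)ccc1Cl`, gives 1770 nM.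

Compound 3 carries the highest of the three numbers, but its neighbours are close: a 1.2-fold higher number from compound 1 to compound 3 (0.09 log units; within the scatter) and a 1.9-fold higher number from compound 2 to compound 3 (0.27 log units; within the scatter), so none of the three can be told apart with confidence.

Compound 4, `COc1cc(-c2nn(-c3cccc(NC(=O)Nc4ccc(Cl)c(C(F)(F)F)c4)c3)cc2-c2ccncc2)ccc1Cl`, has not yet been measured. It differs from compound 3 in one place: (4-chloro-3-(trifluoromethyl)phenyl)amino in place of 4-chloro-3-(trifluoromethyl)phenyl on a carbonyl carbon. In plainer words, the amide of compound 3 becomes a urea, the same kind of change that separates compound 1 from compound 2. That earlier step gave a 1.5-fold lower number from compound 1 to compound 2 (0.19 log units; within the scatter), a small move toward stronger growth inhibition that still sits inside the usual scatter. Within the data shown here, only this one step bears directly on the change at hand, and it gives little reason to expect anything larger here.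

Compound 4 is therefore expected to give about 1150 nM in this assay, with a likely range from 500 nM to 2700 nM. The expected step, a 1.5-fold lower number from compound 3 to compound 4 (0.19 log units; within the scatter), is small and may well fall within the scatter.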

Compound 4, concentration for 50% growth inhibition: 980 nM
Compound 4: middle estimate off by 1.2-fold (0.07 log units), on the high side, within the range that was stated.
By their numbers in this assay, from the lowest: compounds 2, 4, 1 and 3 (each within the scatter of the next).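

The swap of amide for urea now has a second example in this assay, a 1.8-fold lower number from compound 3 to compound 4 (0.26 log units; within the scatter), and like the first it stays within the scatter, so neither example shows a real gain from the urea. Making the urea and chloro changes together gives a 1.5-fold lower number from compound 1 to compound 4 (0.17 log units; within the scatter), which is also within the scatter, so even the two changes combined do not separate the compounds. The chloro on the aromatic carbon can now be read on the urea as well, as a 1.0-fold higher number from compound 2 to compound 4 (0.02 log units; within the scatter), and its step is much the same with either linker: the same change on two cores in this assay, a 1.2-fold higher number (0.09 log units; within the scatter) from compound 1 to compound 3 and a 1.0-fold higher number (0.02 log units; within the scatter) from compound 2 to compound 4, 1.2-fold (0.07 log units) apart, within the scatter of two such steps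

All four compounds lie within the scatter of their neighbours, so they give no ranking and show no sign that this position affects growth inhibition at all. Still open, going by these compounds, is whether a different group on this aromatic ring, such as a nitrile or a morpholine, or a sulfonamide in place of the amide or urea, would move the number beyond the scatter.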